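Aryl swap on the sulfonamide of a shared core

A few compounds are considered here, and "the series" means these few. Any claim that something is new, unique, unknown or untested is made for them only; others in the source may bear on it.

Of the compounds shown here, three sharing one core have been measured in a functional assay on HCT-116 cells (Homo sapiens) for antiproliferative activity, read by MTT assay, with a stated time of 72 h; a higher number here means a weaker inhibitor, a lower number a stronger inhibitor. Compound 1 `CN(C(=O)c1ccc(Cl)cc1)c1ccc2[nH]c(-c3n[nH]c4ccccc34)cc2n1` gives 3000 nM. Compound 2 `COc1ccc(C(=O)N(C)c2ccc3[nH]c(-c4n[nH]c5ccccc45)cc3n2)cc1` gives 29500 nM. Compound 3 `CN(c1ccc2[nH]c(-c3n[nH]c4ccccc34)cc2n1)S(=O)(=O)c1ccc(Cl)cc1` gives 5980 nM. Among these numbers compound 3 stands second highest; the step of a 2.0-fold higher number from compound 1 to compound 3 (0.30 log units; within the scatter) lies within the scatter, while the step of a 4.9-fold lower number from compound 2 to compound 3 (0.69 log units; beyond the scatter) lies beyond it.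

Compound 4 `CN(c1ccc2[nH]c(-c3n[nH]c4ccccc34)cc2n1)S(=O)(=O)c1cccc([N+](=O)[O-])c1` has not yet been measured. It differs from compound 3 in one place: 3-nitrophenyl in place of 4-chlorophenyl on a sulfonyl sulfur.

Within the data shown here, only one measured step changes the substituent on the aryl ring attached to the nitrogen substituent, namely a 9.8-fold higher number from compound 1 to compound 2 (0.99 log units; beyond the scatter), and that step concerns the carbonyl series rather than the sulfonyl series. Among the measured compounds shown here, no measured step exchanges a chloro group for a nitro group, nor moves a substituent to a different position on that ring. The replacement of chloro by another group in the carbonyl series raised the number; carried over to the sulfonyl series, a rise of similar or smaller size is the most that the data support, with wide uncertainty.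

Compound 4 is therefore expected to sit at about 12000 nM in this assay, between 4000 nM and 40000 nM, an estimated step of a 2.0-fold higher number from compound 3 to compound 4 (0.30 log units; within the scatter).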

Compound 4, half-maximal inhibitory concentration: 13600 nM
Compound 4: middle estimate off by 1.1-fold (0.05 log units), on the low side; the range from low to high includes it.
By their numbers in this assay, from the lowest: compounds 1 and 3 (each within the scatter of the next); then compound 4; then compound 2.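

In this assay, the sulfonyl series now has an aryl step of its own: a 2.3-fold higher number from compound 3 to compound 4 (0.36 log units; beyond the scatter), beyond the scatter, shows that the number responds to the aryl group on the sulfonyl sulfur, whereas the earlier aryl step, a 9.8-fold higher number from compound 1 to compound 2 (0.99 log units; beyond the scatter), concerned only the carbonyl series. Both steps leave a 4-chlorophenyl group and both raise the number, but this is a pattern of just two pairs, and the new step changes both the substituent and its place on the ring in a single exchange. The compounds shown offer no measurement that explains the rise.

Among these compounds, how much of the rise belongs to the nitro group itself and how much to its place on the ring remains open, as no compound here changes one without the other. Also open, from the compounds shown here alone, is how the number would respond to an amine or a carboxylic acid on this aryl ring, or to a simple alkyl chain on the sulfonyl sulfur in place of the ring.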